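Methylating the Aromatic Hydroxy Group of Compound 2

A few compounds are considered here, and "the series" means these few. Any claim that something is new, unique, unknown or untested is made for them only; others in the source may bear on it.

In a functional assay on KB cells (Homo sapiens) for cytotoxicity, read by sulforhodamine B assay, with a stated time of 3 days (on this read-out higher numbers stand for an effect only at larger amounts of compound and lower numbers for an effect already at smaller amounts), compound 1 `Cc1coc(-c2ccc3c(c2O)CCCC3(C)C)c1C(=O)O` gives 4.7 uM. Among the measured compounds shown here, compound 2 `Cc1coc(-c2ccc3c(c2O)CCCC3(C)C)c1CO` gives 22 uM, and compound 3 `Cc1coc(-c2ccc3c(c2O)CCC3)c1C(=O)O` gives 31.4 uM, a value within the scatter of the one for compound 2. Compound 2 thus lies beyond the scatter from compound 1. Compound 4 `COc1c(-c2occ(C)c2CO)ccc2c1CCCC2(C)C` differs from compound 2 by methyl in place of hydrogen on an oxygen on an aromatic ring, turning hydroxy into methoxy. For the measured compounds named here, the only measured step, a 4.7-fold higher number from compound 1 to compound 2 (0.67 log units; beyond the scatter), is modest and puts hydroxymethyl in place of carboxy, a different change in a different place. Going by the values given here, no measured pair tests the hydroxy group, so no step beyond the scatter is expected. The expected step is a 1.1-fold higher number from compound 2 to compound 4 (0.06 log units; within the scatter). For compound 4 the estimated value is 25 uM, with an expected range from 10 uM to 60 uM.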

Compound 4, concentration for half-maximal effect: 25.3 uM
Compound 4: the middle estimate sits 1.0-fold (0.01 log units) below what was measured; the measured number falls inside the stated range.
By their numbers in this assay, from the lowest: compound 1; then compounds 2, 4 and 3 (each within the scatter of the next).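

In this assay methyl in place of hydrogen on the oxygen on the aromatic ring gives a 1.2-fold higher number from compound 2 to compound 4 (0.06 log units; within the scatter) and so leaves the number unmoved. Among the compounds shown here, this is the first test of the hydroxy group: with hydroxymethyl on the furan-bearing core, hydroxy and methoxy read alike, so the hydrogen on this oxygen is not needed for the effect at this level. No evidence bearing on the reason accompanies this result. Open remains whether methoxy is equally tolerated alongside the carboxy group of compound 1, and whether an ethoxy group, a longer chain or an amine would be tolerated at this position.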